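The source may report more compounds than this note shows. Statements on the series, on what has been measured and on what is new or still open speak of the compounds shown alone.

Three compounds share one core and differ only in the aryl group attached to a sulfonyl sulfur. Compound 1 `COc1cc(N)c(Cl)cc1C(=O)CCC1CCN(CCNS(=O)(=O)c2cc(Br)ccc2Br)CC1` carries a 2,5-dibromophenyl there, compound 2 `COc1ccc(S(=O)(=O)NCCN2CCC(CCC(=O)c3cc(Cl)c(N)cc3OC)CC2)cc1Cl` a 3-chloro-4-methoxyphenyl, and compound 3 `COc1ccc(S(=O)(=O)NCCN2CCC(CCC(=O)c3cc(Cl)c(N)cc3OC)CC2)c(OC)c1` a 2,4-dimethoxyphenyl. In an assay on HEK293 cells for displacement of a labelled ligand from 5-hydroxytryptamine receptor 6 (Homo sapiens), with a stated time of 60 min, tested at 1 uM, in the presence of a further agent that is not named here (on this read-out lower numbers stand for a weaker effect and higher numbers for a stronger effect at the one concentration tested), compound 1 gives 52%, compound 2 gives 85%, and compound 3 gives 45%. Compound 2 stands highest of the three: the step of a number 33 percentage points higher from compound 1 to compound 2 (beyond the scatter) and the step of a number 40 percentage points lower from compound 2 to compound 3 (beyond the scatter) both lie beyond the scatter, whereas the step of a number 7 percentage points lower from compound 1 to compound 3 (within the scatter) lies within it.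

Compound 4 `COc1cc(N)c(Cl)cc1C(=O)CCC1CCN(CCNS(=O)(=O)c2ccc(OC)c(N3CCN(C)CC3)c2)CC1` departs from compound 2 by a single change on that aryl group: 4-methylpiperazin-1-yl in place of chloro on an aromatic carbon. Among the measured compounds shown here, no measured step exchanges chloro for this group, so the measured steps bear on it only indirectly. They show that altering this aryl group can move the read-out a long way in either direction, and compound 3, whose aryl group carries no chloro, gives 45%. Loss of the chloro is therefore expected to lower the number for compound 4, with the expected step being a number 30 percentage points lower from compound 2 to compound 4 (beyond the scatter), though the uncertainty is wide. The estimate for compound 4 in this assay is 55%, ranging from 25% to 85%.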

Compound 4, a percentage reported as inhibition, at one concentration (the size of the read-out at that concentration, not a potency): 43%
Compound 4: middle estimate off by 12 percentage points, on the high side; the measured number falls inside the stated range.
By their numbers in this assay, from the lowest: compounds 4, 3 and 1 (each within the scatter of the next); then compound 2.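

In this assay, among the compounds shown here, the one step that changes only the group on this aromatic carbon, ortho to a methoxy group, is a number 42 percentage points lower from compound 2 to compound 4 (beyond the scatter). The earlier steps shown here changed the aryl group's substitution in more than one place, whereas here the methoxy group and the sulfonyl attachment stay as they are, so this single exchange of chloro (1 heavy atom) for 4-methylpiperazin-1-yl (7 heavy atoms) is enough to remove compound 2's standing apart from the others, and compounds 4, 3 and 1 now lie each within the scatter of the next. Nothing measured here gives a reason for this drop, so the numbers record the size of the change but do not explain it.

On these data alone, whether the drop comes from losing chloro or from adding the piperazine ring stays open, as both happen in the same step. Plain hydrogen, fluoro or methyl on that carbon would speak to the role of chloro, while a dimethylamino group or a morpholine ring would show how far the result depends on the entering group.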